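Chlorophenyl ketone variation on the shared core

The source may report more compounds than this note shows. Statements on the series, on what has been measured and on what is new or still open speak of the compounds shown alone.

Three ketones on the shared core have been measured in an assay on CHO cells for displacement of a labelled ligand from adenosine receptor A1 (Homo sapiens), read by scintillation counting, tested at 10 uM; a lower number here means less inhibition, a higher number more inhibition at the concentration tested (going by the name of the read-out). Compound 1 `CC(C)(C)Cc1c(-c2ccccc2)sc(N)c1C(=O)c1ccc(Cl)cc1` gives 1%. Compound 2 `CC(C)(C)Cc1c(-c2ccccc2)sc(N)c1C(=O)c1cccc(Cl)c1` gives 2%, and compound 3 `CC(C)(C)Cc1c(-c2ccccc2)sc(N)c1C(=O)c1ccc(Cl)c(Cl)c1` gives 1%. The steps between them stay small: a number 1 percentage points higher from compound 1 to compound 2 (within the scatter), no change at the digits printed from compound 1 to compound 3 (within the scatter) and a number 1 percentage points lower from compound 2 to compound 3 (within the scatter). Compound 3 therefore stands level with compound 1 at the digits shown, the two together the lowest of the three numbers, while all three lie within the usual scatter of one another.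

Compound 4 `CC(C)(C)Cc1c(-c2ccccc2)sc(N)c1C(=O)c1ccc(Cl)cc1Cl` is the next member. It differs from compound 3 in one place: 2,4-dichlorophenyl in place of 3,4-dichlorophenyl on a carbonyl carbon. Within the data shown here, the steps that bear on such a rearrangement of chlorine on the phenyl ring are a number 1 percentage points higher from compound 1 to compound 2 (within the scatter) and a number 1 percentage points lower from compound 2 to compound 3 (within the scatter), neither of which reaches beyond the scatter. No change beyond the scatter is therefore expected in this assay for compound 4. The estimated step is no change at the digits printed from compound 3 to compound 4 (within the scatter). Compound 4 is expected to give 1%, with a range from -5% to 10%.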

Compound 4, a percentage reported as inhibition, at one concentration (the size of the read-out at that concentration, not a potency): 1%
Compound 4: the middle estimate sits on the measured number at the digits printed, and the stated range covers the measured number.
By their numbers in this assay, from the lowest: compounds 1, 3, 4 and 2 (each within the scatter of the next).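

Within this assay, the rearrangement of chlorine on the ketone phenyl ring, 2,4-dichlorophenyl in place of 3,4-dichlorophenyl on a carbonyl carbon, gives no change at the digits printed from compound 3 to compound 4 (within the scatter) and so leaves the number unmoved. The same group set against the single-chlorine ketones gives a number 1 percentage points lower from compound 2 to compound 4 (within the scatter) and no change at the digits printed from compound 1 to compound 4 (within the scatter), so no chlorine pattern among these four stands apart. Chloro in place of hydrogen on an aromatic carbon now reads alike from two starting ketones: the same change on two cores in this assay, a number 1 percentage points lower (within the scatter) from compound 2 to compound 3 and no change at the digits printed (within the scatter) from compound 1 to compound 4, 1 percentage points apart, within the scatter of two such steps.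

All four compounds carry only chlorine on this phenyl ring, so these steps say nothing about the effect of other groups on it. On these data alone, whether an amine, a carboxylic acid or a methoxy group on this ring would move the number beyond the scatter stays open.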